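The source may hold more compounds than are shown below. What is called first, only, known or untested is meant among the compounds shown, and "the series" means these compounds.

Compound 1 `O=C1N=C(N2N=C(c3ccccc3)CC2c2ccccc2O)S/C1=C1/C(=O)Nc2ccccc21`: 36600 nM
Compound 2 `COc1ccc(C2=NN(C3=NC(=O)/C(=C4\C(=O)Nc5ccccc54)S3)C(c3ccc(OC)cc3)C2)cc1`: 100000 nM
Compound 3 `O=C1N=C(N2N=C(c3ccccc3)CC2c2ccc(Cl)cc2)S/C1=C1/C(=O)Nc2ccccc21`: 650 nM

All three compounds share one core and differ only in the groups carried on their aromatic rings. Within the data shown here, in a functional assay on cells (Cancer cell lines, Homo sapiens) for cytotoxicity, read by sulforhodamine B assay, with a stated time of 48 h (on this read-out higher numbers stand for weaker inhibition of growth and lower numbers for stronger inhibition of growth), compound 3 gives the lowest number of the three; the single change a 56-fold lower number from compound 1 to compound 3 (1.75 log units; beyond the scatter) separates it from compound 1, and compound 2 lies even further away. Compound 4 `COc1ccc(C2=NN(C3=NC(=O)/C(=C4\C(=O)Nc5ccccc54)S3)C(c3ccc(Cl)cc3)C2)cc1` has not yet been measured. It differs from compound 3 in one spot: methoxy in place of hydrogen on an aromatic carbon. Among the measured compounds shown here, no measured pair isolates this particular change. The step of a 56-fold lower number from compound 1 to compound 3 (1.75 log units; beyond the scatter) bears on it only indirectly, by showing that one alteration on an aromatic ring of this core can move the number a great deal. Compound 2 carries a methoxy on each of its two aromatic rings and gives a far higher number than compound 3, but it also has 4-methoxyphenyl where compound 3 has 4-chlorophenyl, so the two alterations cannot be pulled apart. On that evidence the added methoxy is expected to weaken growth inhibition somewhat, with wide uncertainty. Compound 4 is therefore estimated to give 2000 nM in this assay, within a range of 500 nM to 10000 nM. That estimate corresponds to an expected step of a 3.1-fold higher number from compound 3 to compound 4 (0.49 log units; beyond the scatter).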

Compound 4, concentration for total growth inhibition: 100000 nM
Compound 4: the middle estimate sits 50-fold (1.70 log units) below what was measured, and the stated range ends below it.
By their numbers in this assay, from the lowest: compound 3; then compound 1; then compounds 2 and 4 (each within the scatter of the next).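

In this assay, among these compounds, the methoxy on this aromatic carbon, para to a large group, proves decisive on its own: the single change gives a 150-fold higher number from compound 3 to compound 4 (2.19 log units; beyond the scatter) and so removes nearly all of the growth inhibition seen with the phenyl ring of compound 3. Compound 2 could not show this, since it differs from compound 3 in two places at once. With this methoxy in place, chloro in place of methoxy on the second aromatic ring gives no change at the digits printed from compound 2 to compound 4 (within the scatter) and so the 4-chlorophenyl group, which compound 3 carries along with its low number, brings no gain in compound 4.

Nothing available here explains why one methoxy has so large an effect. The compounds shown leave open whether the loss belongs to methoxy itself or to any group larger than hydrogen on this carbon, which a fluorine, a hydroxyl, an amine or a longer chain such as butoxy at the same spot would help to separate, and whether chloro would then matter again.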